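Salicylanilide series: dipropylamino to (cyclopentylmethyl)amino, cytotoxicity

The source may report more compounds than this note shows. Statements on the series, on what has been measured and on what is new or still open speak of the compounds shown alone.

For the measured compounds named here, compound 1 `CCCN(CCC)c1ccc(NC(=O)c2cc(Cl)ccc2O)c(Cl)c1` stands highest of the two numbers so far: in an ADME assay on A549 cells (Homo sapiens) for cytotoxicity, read by LDH release, with a stated time of 15 h (on this read-out higher numbers stand for lower toxicity in this test and lower numbers for higher toxicity in this test), compound 1 gives 323000 nM. Its nearest neighbour, compound 2 `O=C(Nc1ccc(NCc2cc(C(F)(F)F)cc(C(F)(F)F)c2)cc1Cl)c1cc(Cl)ccc1O`, gives 22900 nM in this assay, a gap beyond the scatter. Compound 3 `O=C(Nc1ccc(NCC2CCCC2)cc1Cl)c1cc(Cl)ccc1O` carries (cyclopentylmethyl)amino in place of dipropylamino on an aromatic carbon. Going by the values given here, no measured pair isolates this change. A modest drop in the number is expected, less than the gap between compound 1 and compound 2; the expected step is a 2.2-fold lower number from compound 1 to compound 3 (0.33 log units; beyond the scatter). Compound 3 is estimated at 150000 nM, with a range of 50000 nM to 450000 nM.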

Compound 3, half-maximal cytotoxic concentration: 141000 nM
Compound 3: the middle estimate sits 1.1-fold (0.03 log units) above what was measured; low and high end bracket the measured number.
By their numbers in this assay, from the lowest: compound 2; then compound 3; then compound 1.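

In this assay, (cyclopentylmethyl)amino in place of dipropylamino on this aromatic carbon gives a 2.3-fold lower number from compound 1 to compound 3 (0.36 log units; beyond the scatter), the first step read at this position. The change keeps the heavy-atom count but brings in a five-membered non-aromatic ring and a hydrogen-bond donor together, so this single step cannot separate the two. No measurement here points to a cause for the step.

Still open, going by these compounds, is which of the two features goes with the lower number. A hexylamino group would keep the donor without the ring, while an N-methyl(cyclopentylmethyl)amino group would keep the ring without the donor.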